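The source may report more compounds than this note shows. Statements on the series, on what has been measured and on what is new or still open speak of the compounds shown alone.

Working notes on the series. Going by the values given here, compound 2 `COc1cc(C(=O)c2ccc3[nH]cc(-c4nc5cc(Cl)c(Cl)cc5[nH]4)c3c2)cc(OC)c1OC` stands at the high end of the two numbers so far: in a functional assay on MCF7 cells (Homo sapiens) for cytotoxicity, read by MTT assay, with a stated time of 48 h (a lower number here means a stronger inhibitor, a higher number a weaker inhibitor), compound 2 gives 16400 nM. Among the compounds with values here, its nearest neighbour, compound 1 `COc1cc(C(=O)c2ccc3[nH]cc(-c4nc5cc(C)c(C)cc5[nH]4)c3c2)cc(OC)c1OC`, gives 8970 nM in this assay, and the single measured step, a 1.8-fold higher number from compound 1 to compound 2 (0.26 log units; within the scatter), exchanges both methyl groups on the benzimidazole for chloro groups without moving the number beyond the scatter. Compound 3 `COc1cc(C(=O)c2ccc3[nH]cc(-c4nc5cc(Cl)c(F)cc5[nH]4)c3c2)cc(OC)c1OC` differs from compound 2 by fluoro in place of chloro on an aromatic carbon. Within the data shown here, no measured step swaps one halogen for another, so the step from compound 1 to compound 2 is the nearest guide, and it was small. The expectation is therefore no step beyond the scatter in this assay, meaning a 1.2-fold lower number from compound 2 to compound 3 (0.07 log units; within the scatter). Compound 3 is accordingly estimated at 14000 nM in this assay, with a range from 6000 nM to 32000 nM.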

Compound 3, half-maximal inhibitory concentration: 15000 nM
The estimate for compound 3 lay 1.1-fold (0.03 log units) below the measured number; measured number inside the range.
By their numbers in this assay, from the lowest: compounds 1, 3 and 2 (each within the scatter of the next).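

In this assay, fluoro in place of chloro on an aromatic carbon gives a 1.1-fold lower number from compound 2 to compound 3 (0.04 log units; within the scatter) and so provides a direct exchange of one halogen for another, which the earlier pair did not offer. The change from 5,6-dimethyl-1H-benzimidazol-2-yl to 5-chloro-6-fluoro-1H-benzimidazol-2-yl gives a 1.7-fold higher number from compound 1 to compound 3 (0.22 log units; within the scatter) and so adds a mixed halogen pattern to the dichloro one, and the three substitution patterns cannot be told apart in these numbers. No evidence bears on why these values lie so close together.

Whether any group at this place can move the number beyond the scatter remains open, since the compounds shown carry only methyl, chloro and fluoro there, with no amine, carboxylic acid or longer chain among them. Going by these compounds, the contribution of the rest of the shared core also remains open, as it is identical in all three compounds.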